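Lengthening the Acid Side Chain of Compound 3

This account rests on a few compounds, and the source may have more. Where it says the series, first, only, none or still open, it means among the compounds named here.

In a functional assay for inhibition, with Homo sapiens as the target (a lower number here means a stronger inhibitor, a higher number a weaker inhibitor), compound 1 `O=C(O)CCc1c(-c2cccnc2)ccc2c1CCC(NS(=O)(=O)c1ccc(Cl)cc1)C2` comes in at 140 nM while compound 2 `Cc1c(Cc2cccnc2)cc2c(c1CCC(=O)O)CCC(NS(=O)(=O)c1ccc(Cl)cc1)C2` comes in at 610 nM and compound 3 `O=C(O)CC/C=C/c1c(Cc2cccnc2)ccc2c1CCC(NS(=O)(=O)c1ccc(Cl)cc1)C2` comes in at 47 nM as the lowest of the three. The gaps from compound 3 to each of the other two lie beyond the usual scatter of repeated measurements, so compound 3 is the strongest inhibitor so far. It carries a 4-carboxybut-1-en-1-yl group on an aromatic carbon, ortho to a (pyridin-3-yl)methyl group.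

Compound 4 `O=C(O)CCC/C=C\c1c(Cc2cccnc2)ccc2c1CCC(NS(=O)(=O)c1ccc(Cl)cc1)C2` is still unmeasured, and it differs from compound 3 at that group (5-carboxypent-1-en-1-yl in place of 4-carboxybut-1-en-1-yl on an aromatic carbon) with 5-carboxypent-1-en-1-yl in place of 4-carboxybut-1-en-1-yl on an aromatic carbon. Among the compounds with values here, no measured pair shows this kind of change on its own, so the expectation rests mainly on compound 3 at 47 nM as a starting point. The expected result is a 1.5-fold higher number from compound 3 to compound 4 (0.17 log units; within the scatter) which would be a small move toward weaker inhibition and may well stay within the scatter. Compound 4 is estimated at 70 nM with an expected range of 20 nM to 250 nM in this measurement.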

Compound 4, half-maximal inhibitory concentration: 160 nM
For compound 4 the middle estimate is 2.3-fold (0.36 log units) below the measured one; the measured number falls inside the stated range.
By their numbers in this assay, from the lowest: compound 3; then compounds 1 and 4 (each within the scatter of the next); then compound 2.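

Adding one carbon to the acid side chain is not a neutral change at this position: in this assay, putting 5-carboxypent-1-en-1-yl in place of 4-carboxybut-1-en-1-yl gives a 3.4-fold higher number from compound 3 to compound 4 (0.53 log units; beyond the scatter). Within the data shown here, this is the first pair that differs in only one place, so it gives the first direct reading of how this position responds, and here the shorter 4-carboxybut-1-en-1-yl group gives the stronger inhibition. Nothing measured here explains this loss of strength, so its reason stays unknown.

The double bond is also drawn differently, trans in compound 3 and cis in compound 4, so this single step cannot separate the effect of chain length from that of double-bond geometry. Also open, as far as these compounds go, is how the same core would fare with a trans 5-carboxypent-1-en-1-yl group, a fully saturated chain of either length, or a longer chain such as 6-carboxyhex-1-en-1-yl.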